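The compounds below may be only part of what the source reports. "The series", "measured", "known", "first", "only" and "open" are said of these compounds alone.

Measured in a functional assay on DU-145 cells (Homo sapiens) for inhibition, read by trypan blue exclusion, with a stated time of 96 h; a higher number here means a weaker inhibitor of growth, a lower number a stronger inhibitor of growth:
- compound 1 `O=C(O)c1ccc(C(=O)/C(=C\c2ccc(O)c([N+](=O)[O-])c2)SCc2ccc(Br)cc2)cc1`: 50000 nM
- compound 2 `O=C(/C(=C\c1ccc(O)c([N+](=O)[O-])c1)SCc1ccc(Br)cc1)c1ccc(Br)cc1`: 10000 nM
- compound 3 `COc1ccc(C(=O)/C(=C\c2ccc(O)c([N+](=O)[O-])c2)SCc2ccc(Br)cc2)cc1`: 10000 nM

Compound 2 is level with compound 3, and these two share the lowest number of the set. Compound 1 lies apart, with a 5.0-fold lower number from compound 1 to compound 2 (0.70 log units; beyond the scatter).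

Compound 4 `COc1cc(/C=C(/SCc2ccc(Br)cc2)C(=O)c2ccc(Br)cc2)cc([N+](=O)[O-])c1O` has methoxy in place of hydrogen on an aromatic carbon, ortho to a hydroxy group.

Among the measured compounds shown here, no measured step changes this place, so the evidence is indirect. Elsewhere, a 5.0-fold lower number from compound 1 to compound 3 (0.70 log units; beyond the scatter), while methoxy for bromo gives no change at the digits printed from compound 2 to compound 3 (within the scatter). A small effect is therefore expected, with no change at the digits printed from compound 2 to compound 4 (within the scatter) as the estimated step in this assay, none beyond the scatter. Compound 4 is expected at 10000 nM, within an estimated range of 4000 nM to 30000 nM.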

Compound 4, concentration for 50% growth inhibition: 25000 nM
Compound 4: the middle estimate sits 2.5-fold (0.40 log units) below what was measured; low and high end bracket the measured number.
By their numbers in this assay, from the lowest: compounds 2 and 3 (each within the scatter of the next); then compounds 4 and 1 (each within the scatter of the next).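

In this assay, methoxy in place of hydrogen on this aromatic carbon, ortho to a hydroxy group, gives a 2.5-fold higher number from compound 2 to compound 4 (0.40 log units; beyond the scatter). Among the compounds shown here, the earlier steps all changed a different aromatic position, so this is the first sign that this carbon also affects growth inhibition, and here the change weakens it. Nothing measured accounts for the step.

Going by these compounds, whether an amine or a longer alkoxy chain on this carbon would shift the number the same way remains open. On these data alone, it is also open whether the step would hold on the core of compound 3.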